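Alpha-1D binding: swapping a methyl for a methoxy group

The source may report more compounds than this note shows. Statements on the series, on what has been measured and on what is new or still open speak of the compounds shown alone.

Measured compounds:
compound 1 `COc1cccc(OC)c1OCCNCCOc1ccccc1OCc1ccccc1`, 0.0676 nM
compound 2 `COc1cccc(OC)c1OCCNCCOc1ccccc1OCc1cccc(C)c1`, 0.2 nM

In an assay on CHO cells for displacement of a labelled ligand from Alpha-1D adrenergic receptor (Homo sapiens) (a higher number here means a weaker inhibitor, a lower number a stronger inhibitor), compound 2 gives the higher of the two numbers shown, so it is the weaker of the pair; the only other compound, compound 1, gives a lower number 0.0676 nM. For the measured compounds named here, the one measured step, a 3.0-fold higher number from compound 1 to compound 2 (0.47 log units; beyond the scatter), shows that methyl in place of hydrogen on an aromatic carbon weakens binding modestly. Compound 3 `COc1ccccc1COc1ccccc1OCCNCCOc1c(OC)cccc1OC` carries a different change: 2-methoxyphenyl in place of 3-methylphenyl on a saturated chain carbon bound to an oxygen on an aromatic ring. Going by the values given here, no measured step tests a methoxy group at that place, so the change can only be judged loosely against the methyl step. A small shift in either direction within this assay seems as likely as none beyond the scatter. Compound 3 is therefore expected to land near compound 2, estimated at 0.12 nM (range 0.03 nM to 0.5 nM), a step of a 1.7-fold lower number from compound 2 to compound 3 (0.22 log units; within the scatter).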

Compound 3, inhibition constant: 2 nM
The estimate for compound 3 lay 17-fold (1.22 log units) below the measured number; the whole stated range lies below it.
By their numbers in this assay, from the lowest: compound 1; then compound 2; then compound 3.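

At this place, on a saturated chain carbon bound to an oxygen on an aromatic ring, the two substituted phenyl groups are not interchangeable: 2-methoxyphenyl in place of 3-methylphenyl gives a 10-fold higher number from compound 2 to compound 3 (1.00 log units; beyond the scatter) in this assay, so this change matters more than the small methyl step suggested. Measured against the plain phenyl group, the methoxy change gives a 30-fold higher number from compound 1 to compound 3 (1.47 log units; beyond the scatter) and the methyl change gives a 3.0-fold higher number from compound 1 to compound 2 (0.47 log units; beyond the scatter), so both added groups weaken binding here, the methoxy group by more, although they also sit at different places on the ring. Nothing available explains this loss of binding.

The effect of the group therefore cannot yet be separated from the effect of its ring place. A 3-methoxyphenyl or 2-methylphenyl group would test that, and a fluorine atom or hydroxyl group at either place would show how general the weakening is.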